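The compounds below may be only part of what the source reports. "The series", "measured", "known", "first", "only" and "open" are said of these compounds alone.

Compound 1 `COc1cc2c(Nc3ccc(C#N)cc3)ncnc2cc1OCCCN(C)C` carries a dimethylamino group on the chain. In a functional assay on HepG2 cells (Homo sapiens) for antiproliferative activity, read by MTT assay, with a stated time of 72 h (on this read-out lower numbers stand for stronger inhibition and higher numbers for weaker inhibition), compound 1 gives only a limit of the assay, > 100000 nM, so no number is known for it (the limit of > 100000 nM in this assay, at which 1 of the 3 values shown sits). Compound 2 `COc1cc2c(Nc3ccc(C#N)cc3)ncnc2cc1OCCCN1CCCCC1` gives 20700 nM in this assay, and compound 3 `COc1cc2c(Nc3ccc(C#N)cc3)ncnc2cc1OCCCN1CCC(CO)CC1` gives 61800 nM. The step of an at least 4.8-fold lower number from compound 1 to compound 2 (0.68 log units; beyond the scatter) and the step of an at least 1.6-fold lower number from compound 1 to compound 3 (0.20 log units; that floor lies within the scatter) both run downward from the limit, while the step of a 3.0-fold higher number from compound 2 to compound 3 (0.48 log units; beyond the scatter) runs upward.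

Compound 4 `COc1cc2c(Nc3ccc(C#N)cc3)ncnc2cc1OCCCN1CCCCC1CCO` differs from compound 1 by 2-(2-hydroxyethyl)piperidin-1-yl in place of dimethylamino on a saturated chain carbon, three bonds along the chain from an oxygen on an aromatic ring. The closest measured steps are those to compound 2 and compound 3, which both place a piperidinyl ring where the dimethylamino group stood; compound 4 adds a hydroxyethyl group to such a ring, and the step from compound 2 to compound 3 shows a hydroxy-bearing group on the ring raising the number. A downward step from the limit is therefore expected, estimated as an at least 2.5-fold lower number from compound 1 to compound 4 (0.39 log units; beyond the scatter). Compound 4 is expected to give 40000 nM, in the range 15000 nM to 100000 nM.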

Compound 4, half-maximal inhibitory concentration: > 100000 nM
Compound 4: a limit, no number; the forecaster's own chance of this, stated with the estimate: 25%; middle value at least 2.5-fold (0.39 log units) away from the limit.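

In this assay compound 4 gives only a limit, as compound 1 does, so the step between these two cannot be read: the limit of > 100000 nM in this assay, at which 2 of the 4 values shown sit.

Adding a hydroxy-bearing group to the ring gives an at least 4.8-fold higher number from compound 2 to compound 4 (0.68 log units; beyond the scatter), so having a ring at this place on the chain does not by itself keep the value seen for compound 2. The change of ring substituent read against the other hydroxy-bearing compound is only an at least 1.6-fold higher number from compound 3 to compound 4 (0.20 log units; that floor lies within the scatter) and does not separate the two.

On these data alone, it remains open whether a 4-(2-hydroxyethyl)piperidin-1-yl group would read like compound 3 or like compound 4. Also open, as far as these compounds go, is how a morpholin-4-yl or piperazin-1-yl group, or a longer chain, would read in this assay.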